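Cyclohexyl to butyl on the ring nitrogen

The compounds below may be only part of what the source reports. "The series", "measured", "known", "first", "only" and "open" are said of these compounds alone.

Three measured compounds share one core and differ only in the group on one aromatic carbon. Compound 1 `CNc1nc(N)nc2c1ncn2/C=C1/CC1(CO)CO` carries methylamino there, compound 2 `Nc1nc(N2CCCC2)c2ncn(/C=C3/CC3(CO)CO)c2n1` pyrrolidin-1-yl and compound 3 `Nc1nc(NC2CCCCC2)c2ncn(/C=C3/CC3(CO)CO)c2n1` cyclohexylamino. In an ADME assay on Akata cells (Homo sapiens) for cytotoxicity, with a stated time of 7 days (a lower number here means that less compound is tolerated, a higher number that more compound is tolerated), compound 1 reaches only a limit, > 24000 nM. In this assay compound 2 likewise gives only a limit, > 24000 nM. Compound 3 also gives only a limit, > 24000 nM. Compound 3 thus stands where every value of the series stands so far, at the limit of > 24000 nM in this assay, at which 3 of the 3 values shown sit. The steps a step that the two limits leave unreadable from compound 1 to compound 2, a step that the two limits leave unreadable from compound 1 to compound 3 and a step that the two limits leave unreadable from compound 2 to compound 3 are unreadable for that reason. Compound 4 `CCCCNc1nc(N)nc2c1ncn2/C=C1/CC1(CO)CO` differs from compound 3 by butyl in place of cyclohexyl on a nitrogen on an aromatic ring. Within the data shown here, no measured step can be sized, so none bears a readable size on this change; what the three values show is that each variation at this position has left the read-out at the limit. For compound 4 the step that the limit leaves unreadable from compound 3 to compound 4 is expected to be nil within the scatter, the value most likely again a limit. Compound 4 is estimated at 40000 nM, between 15000 nM and 120000 nM.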

Compound 4, half-maximal cytotoxic concentration: > 24000 nM
Compound 4: no number, only a limit; the forecaster's own chance of this, stated with the estimate: 85%; the middle value is on the limit's open side.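

No step from compound 1, compound 2 or compound 3 to compound 4 can be read in this assay, since all four sit at one limit: the limit of > 24000 nM in this assay, at which 4 of the 4 values shown sit.

The compounds shown leave open at what concentration any of them turns cytotoxic, and whether the group on this aromatic carbon alters that concentration.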